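Branching the imidazole substituent: from ethyl to isopropyl

A few compounds are considered here, and "the series" means these few. Any claim that something is new, unique, unknown or untested is made for them only; others in the source may bear on it.

Measured so far:
Compound 1, `Cn1ccnc1/C=C/C(=O)/C=C/c1coc2ccccc2c1=O`: 2300 nM
Compound 2, `CCn1ccnc1/C=C/C(=O)/C=C/c1coc2ccccc2c1=O`: 1000 nM
Compound 3, `CCCCCn1ccnc1/C=C/C(=O)/C=C/c1coc2ccccc2c1=O`: 1800 nM

These three compounds share one core and differ only in the group on the imidazole nitrogen. In a functional assay on LNCaP cells (Homo sapiens) for inhibition, read by WST assay, with a stated time of 3 days (a lower number here means a stronger inhibitor, a higher number a weaker inhibitor), compound 2 gives the lowest of the three numbers, though its distance to compound 3 stays within the scatter; only its distance to compound 1 is beyond it.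

Compound 4, `CC(C)n1ccnc1/C=C/C(=O)/C=C/c1coc2ccccc2c1=O`, has not yet been measured. It differs from compound 2 in one place: methyl in place of hydrogen on a saturated chain carbon bound to an aromatic nitrogen and a saturated chain carbon.

Within the data shown here, two measured steps bear on this. The step of a 2.3-fold lower number from compound 1 to compound 2 (0.36 log units; beyond the scatter) added a methyl on the same kind of carbon and gave a modest gain. The step of a 1.8-fold higher number from compound 2 to compound 3 (0.26 log units; within the scatter) lengthened the chain further and stayed within the scatter. A second methyl on the carbon bound to the aromatic nitrogen is a smaller change than either, so compound 4 is expected to land close to compound 2, with a step of a 1.2-fold higher number from compound 2 to compound 4 (0.08 log units; within the scatter) that is within the scatter. The estimate for compound 4 in this assay is 1200 nM, with a range from 500 nM to 3000 nM.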

Compound 4, half-maximal inhibitory concentration: 1200 nM
The estimate for compound 4 equals the measured number at the digits printed; the range from low to high includes it.
By their numbers in this assay, from the lowest: compounds 2, 4, 3 and 1 (each within the scatter of the next, the first and the last beyond it).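

In this assay, the step that turns ethyl into isopropyl gives a 1.2-fold higher number from compound 2 to compound 4 (0.08 log units; within the scatter) and so shows that a branch on this saturated chain carbon bound to an aromatic nitrogen can be carried with no change that can be told from scatter. The other two comparisons, a 1.5-fold lower number from compound 3 to compound 4 (0.18 log units; within the scatter) and a 1.9-fold lower number from compound 1 to compound 4 (0.28 log units; within the scatter) are also within the scatter, which leaves the difference between compound 1 and compound 2 as the only one in this set that lies beyond it. No measured evidence here accounts for these numbers.

On these data alone, it remains open whether a bulkier branched group such as tert-butyl, a small ring such as cyclopropyl, or a chain ending in an amine would stay in this range. How any of these groups would read on a different core is also unknown.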